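Allyloxy to (ethoxycarbonyl)methoxy on the aromatic nitrogen

This account rests on a few compounds, and the source may have more. Where it says the series, first, only, none or still open, it means among the compounds named here.

Among the measured compounds shown here, in a functional assay on a cell-free system (plasma, Oryctolagus cuniculus) for inhibition, with stated times of 5 min, 1 min and 6 min (a higher number here means a weaker inhibitor, a lower number a stronger inhibitor), compound 1 `CCOC(=O)c1c(C)nc(-c2cccc(C#N)c2)n1C` gives 22100 nM and compound 2 `C=CCOn1c(-c2cccc(C#N)c2)nc(C)c1C(=O)OCC` gives 5860 nM as the lower of the two numbers so far.

Compound 3 `CCOC(=O)COn1c(-c2cccc(C#N)c2)nc(C)c1C(=O)OCC` alters the same substituent, with ethoxycarbonyl in place of vinyl on a saturated chain carbon bound to an oxygen on an aromatic ring as the full difference.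

For the measured compounds named here, no measured step tests this change directly. Going by the values given here, the only guide is a 3.8-fold lower number from compound 1 to compound 2 (0.58 log units; beyond the scatter) with allyloxy in place of methyl on an aromatic nitrogen, a modest step beyond the scatter. It gives no direction for the new change, so no shift beyond the scatter is expected.

The estimated step is a 1.2-fold higher number from compound 2 to compound 3 (0.08 log units; within the scatter) in this assay as a working figure. For compound 3 the expected value is 7000 nM with an estimated range of 2500 nM to 20000 nM for this series.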

Compound 3, half-maximal inhibitory concentration: 6800 nM
Compound 3: middle estimate off by 1.0-fold (0.01 log units), on the high side; the range from low to high includes it.
By their numbers in this assay, from the lowest: compounds 2 and 3 (each within the scatter of the next); then compound 1.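

Replacing vinyl with ethoxycarbonyl on a saturated chain carbon bound to an oxygen on an aromatic ring gives a 1.2-fold higher number from compound 2 to compound 3 (0.06 log units; within the scatter) in this assay, so a chain with 5 heavy atoms and 2 hydrogen-bond acceptors in the entering group reads the same as allyloxy at this place. Among the compounds shown here, the gain over methyl on the aromatic nitrogen therefore appears with a second, different oxygen-linked substituent, at a 3.3-fold lower number from compound 1 to compound 3 (0.51 log units; beyond the scatter), and the series holds no compound that goes against this. No data at hand explain either step.

The compounds shown do not separate the contribution of the oxygen link from that of the chain beyond it. Also open, on these data alone, is whether a carboxylic acid in place of the terminal ethyl ester, an amine on the chain or a longer chain would give a number beyond the scatter of compound 2 and compound 3.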